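Replacing thiophen-2-yl with 3,4-dimethoxyphenyl: an expected cytotoxicity

The source may hold more compounds than are shown below. What is called first, only, known or untested is meant among the compounds shown, and "the series" means these compounds.

Compound 1 `COc1cc(/C=C/C(=O)/C=C/c2cccs2)ccc1OCc1cn(CCOc2cc(=O)oc3ccccc23)nn1` gives 7140 nM
Compound 2 `COc1cccc(/C=C/C(=O)/C=C/c2ccc(OCc3cn(CCOc4cc(=O)oc5ccccc45)nn3)c(OC)c2)c1` gives 7130 nM

In a functional assay on THP-1 cells (Homo sapiens) for cytotoxicity, read by sulforhodamine B assay, with a stated time of 48 h (on this read-out higher numbers stand for weaker inhibition and lower numbers for stronger inhibition), compound 1 gives 7140 nM and compound 2 gives 7130 nM. Going by the values given here, these are the only two numbers so far, and they stand level with each other. Compound 3 `COc1ccc(/C=C/C(=O)/C=C/c2ccc(OCc3cn(CCOc4cc(=O)oc5ccccc45)nn3)c(OC)c2)cc1OC` has not yet been measured. It departs from compound 1 at one place: 3,4-dimethoxyphenyl in place of thiophen-2-yl on a double-bonded chain carbon bound to a double-bonded chain carbon. Cut one bond further out, the same difference reads 2-(thiophen-2-yl)ethenyl to 2-(3,4-dimethoxyphenyl)ethenyl.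

Among the compounds with values here, only one measured step bears on this change. At the same place, 3-methoxyphenyl in place of thiophen-2-yl gave a 1.0-fold lower number from compound 1 to compound 2 (0.00 log units; within the scatter). Within the data shown here, no measured compound yet carries the 3,4-dimethoxyphenyl group, so this single step is a limited guide. With that caution, no shift beyond the scatter is expected in this assay, and the estimated step is a 1.0-fold lower number from compound 1 to compound 3 (0.01 log units; within the scatter). For compound 3 the expected value is 7000 nM, with an estimated range from 3000 nM to 16000 nM.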

Compound 3, half-maximal inhibitory concentration: 2340 nM
For compound 3 the middle estimate is 3.0-fold (0.48 log units) above the measured one; the whole stated range lies above it.
By their numbers in this assay, from the lowest: compound 3; then compounds 2 and 1 (each within the scatter of the next).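

In this assay, going by these compounds alone, 3,4-dimethoxyphenyl is the first group at this place, on a double-bonded chain carbon bound to a double-bonded chain carbon, to move the number beyond the scatter, with a 3.1-fold lower number from compound 1 to compound 3 (0.48 log units; beyond the scatter). Since thiophen-2-yl and 3-methoxyphenyl stand level, a six-membered aromatic ring with one methoxy is not enough on these compounds, and the further step of methoxy in place of hydrogen on an aromatic carbon goes with the stronger inhibition, at a 3.0-fold lower number from compound 2 to compound 3 (0.48 log units; beyond the scatter). Nothing given here accounts for this shift, and the size of the step is all that can be reported.

As far as these compounds go, it remains open whether the added methoxy would give a similar step without the methoxy already present in compound 2, and whether a plain phenyl, a hydroxy group, an amine or a longer ethoxy chain at this place would lower the number as well. All three compounds also share the core of compound 1, so whether the step would carry over to a different core is equally unsettled.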